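The compounds below may be only part of what the source reports. "The series", "measured", "known", "first", "only" and "open" are said of these compounds alone.

Compound 1 `COc1cccc(NC(=O)c2nnn(CC3CCN(C(C)=O)CC3)c2N)c1`: > 250000 nM
Compound 2 `COc1cccc(NC(=O)c2nnn(CC3CCNCC3)c2N)c1`: > 250000 nM

In a physicochemical assay for solubility, read by nephelometry, at pH 7.4 (on this read-out higher numbers stand for higher solubility and lower numbers for lower solubility), compound 2 gives > 250000 nM, which is a limit of the assay and not a number. Compound 1 gives > 250000 nM, likewise a limit. So far the data show (the limit of > 250000 nM in this assay, at which 2 of the 2 values shown sit). Compound 3 `COc1cccc(NC(=O)c2nnn(CC3CCN(C(=O)OC(C)(C)C)CC3)c2N)c1` is compound 2 with one change: tert-butoxycarbonyl in place of hydrogen on an amine nitrogen in a ring. Among the compounds with values here, the only measured step that bears on this is a step that the two limits leave unreadable from compound 1 to compound 2, so it offers no size to carry over. A modest fall is expected, though compound 3 may yet stay at the limit. The expected change is an at least 2.0-fold lower number from compound 2 to compound 3 (0.31 log units; beyond the scatter). Compound 3 is estimated at 120000 nM, with an expected range of 30000 nM to 250000 nM.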

Compound 3, solubility: 39000 nM
Compound 3: the middle estimate sits 3.1-fold (0.49 log units) above what was measured, and the stated range covers the measured number.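

In this assay, this ring nitrogen now gives a readable change: tert-butoxycarbonyl in place of hydrogen brings an at least 6.4-fold lower number from compound 2 to compound 3 (0.80 log units; beyond the scatter). On the same nitrogen, tert-butoxy in place of methyl on the carbonyl carbon brings an at least 6.4-fold lower number from compound 1 to compound 3 (0.80 log units; beyond the scatter). Compound 3 alone of the three has a measured number, so the true size of both steps stays unknown and the step between the other two cannot be read: the limit of > 250000 nM in this assay, at which 2 of the 3 values shown sit.

As far as these compounds go, whether a benzyl or a plain ethyl group on this nitrogen would also come off the limit remains open.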